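This account rests on a few compounds, and the source may have more. Where it says the series, first, only, none or still open, it means among the compounds named here.

Compound 2, `CC(CC[C@H]1/C(=C/c2ccc(F)cc2)CC[C@H]2C(C)(C)CCC[C@]12C)CC(=O)O`, stands at a limit in an ADME assay on HUVEC cells (Homo sapiens) for cytotoxicity, read by MTT assay, with a stated time of 72 h; on this read-out lower numbers stand for stronger inhibition and higher numbers for weaker inhibition: compound 2 gives > 200000 nM, which is a limit of the assay rather than a number. Compound 1, `Cc1ccc(/C=C2\CC[C@H]3C(C)(C)CCC[C@]3(C)[C@H]2CCC(C)CC(=O)O)cc1`, likewise gives only a limit, > 200000 nM. For the measured compounds named here, the one measured step, a step that the two limits leave unreadable from compound 1 to compound 2, is therefore unreadable, as both values sit at the limit of > 200000 nM in this assay, at which 2 of the 2 values shown sit. Compound 3, `CC(CC[C@H]1/C(=C/c2ccc(I)cc2)CC[C@H]2C(C)(C)CCC[C@]12C)CC(=O)O`, differs from compound 2 by iodo in place of fluoro on an aromatic carbon. No readable step bears on this change, so nothing beyond the scatter is expected. Compound 3 is estimated at 200000 nM, within 60000 nM to 600000 nM, an expected step of a number no higher from compound 2 to compound 3 (the limit leaves the size open).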

Compound 3, half-maximal inhibitory concentration: 100000 nM
The estimate for compound 3 lay 2.0-fold (0.30 log units) above the measured number; low and high end bracket the measured number.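

In this assay, compound 3 is the only one of the three to give a number rather than a limit, so a change at this place on the aromatic ring can now be read, if only in part. Iodo in place of fluoro gives an at least 2.0-fold lower number from compound 2 to compound 3 (0.30 log units; that floor lies within the scatter), and iodo in place of methyl gives an at least 2.0-fold lower number from compound 1 to compound 3 (0.30 log units; that floor lies within the scatter). The full size of both steps stays unknown because the other two values are limits: the limit of > 200000 nM in this assay, at which 2 of the 3 values shown sit.

Going by these compounds, how chloro, bromo, a nitrile or an amine would read at this place remains open.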